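The compounds below may be only part of what the source reports. "The series", "measured", "known", "first", "only" and "open" are said of these compounds alone.

Among the compounds with values here, in a functional assay on HeLa cells (Homo sapiens) for inhibition, read by sulforhodamine B assay (on this read-out lower numbers stand for stronger inhibition and higher numbers for weaker inhibition), compound 3 (`Cc1ccc(NC2=CC(=O)c3nc4n(c3C2=O)[C@H]2OC[C@@H](O)[C@H]2OC4)cc1C`) gives 2690 nM as the only true number among the three measured compounds, and it is the strongest of them. Compound 1 (`O=C1C=C(NCc2ccccc2)C(=O)c2c1nc1n2[C@H]2OC[C@@H](O)[C@H]2OC1`) stands at > 8000 nM as a limit of the assay, not a number. Compound 2 (`O=C1C=C(N2CCC2)C(=O)c2c1nc1n2[C@H]2OC[C@@H](O)[C@H]2OC1`) stands at > 16000 nM as a limit too.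

Compound 4 (`CCCN(CCC)C1=CC(=O)c2nc3n(c2C1=O)[C@H]1OC[C@@H](O)[C@H]1OC3`) is still unmeasured. It differs from compound 3 by dipropylamino in place of (3,4-dimethylphenyl)amino on a double-bonded ring carbon on a double-bonded ring carbon of the shared core, with dipropylamino in place of (3,4-dimethylphenyl)amino.

The closest guide is an at least 5.9-fold lower number from compound 2 to compound 3 (0.77 log units; beyond the scatter) on gaining that same (3,4-dimethylphenyl)amino, and the group it replaces there is, as in compound 4, an amine without a hydrogen on its nitrogen. The step of an at least 2.9-fold lower number from compound 1 to compound 3 (0.47 log units; beyond the scatter) on the same gain points the same way. Compound 4 gives up that group, so the direction should reverse. The expected step in this assay is a 4.5-fold higher number from compound 3 to compound 4 (0.65 log units; beyond the scatter) towards weaker inhibition, of modest size. Compound 4 is estimated at 12000 nM with an expected range from 4000 nM to 40000 nM.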

Compound 4, half-maximal inhibitory concentration: > 16000 nM
Compound 4: no number, only a limit; the forecaster's own chance of this, stated with the estimate: 45%; at least 1.3-fold (0.12 log units) between middle value and limit.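

Going to dipropylamino in this assay gives an at least 5.9-fold higher number from compound 3 to compound 4 (0.77 log units; beyond the scatter), so an open-chain amine, like the azetidin-1-yl of compound 2, leaves this double-bonded ring carbon without a measured number. The result for compound 4 is a limit of the assay, not a number, and compound 2 shares it: the limit of > 16000 nM in this assay, at which 2 of the 4 values shown sit. The steps from compound 1 and compound 2 to compound 4 cannot be read, since both ends are limits.

Compound 1 also gives only a limit although it keeps a hydrogen on its amine nitrogen, so the compounds shown cannot separate the part played by that hydrogen from the part played by the aromatic ring of (3,4-dimethylphenyl)amino. Open too, from the compounds shown here alone, is what plain phenylamino, without the two methyl groups, would give, or (3,4-dimethylphenyl)amino with a methyl on its nitrogen.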